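Swapping nitro for methylsulfanyl on a chalcone-like scaffold

The source may report more compounds than this note shows. Statements on the series, on what has been measured and on what is new or still open speak of the compounds shown alone.

Measured compounds:
- compound 1, `COc1cc(C(=O)/C=C/c2cn(C)c3ccccc23)cc(SC)c1OC`: 102 nM
- compound 2, `COc1ccc2c(/C=C/C(=O)c3cc(OC)c(OC)c(SC)c3)c[nH]c2c1`: 101 nM
- compound 3, `COc1cc(C(=O)/C=C/c2c[nH]c3ccccc23)cc([N+](=O)[O-])c1OC`: 1290 nM

All three were tested in a functional assay on MCF7 cells (Homo sapiens) for antiproliferative activity, read by MTT assay, with a stated time of 48 h; on this read-out higher numbers stand for weaker inhibition and lower numbers for stronger inhibition. Compound 1 gives 102 nM in this assay, and compound 2 gives 101 nM; these two numbers lie within the usual scatter of each other. Compound 3 stands apart: in this assay compound 3 gives 1290 nM, the highest of the three numbers, and the gaps to compound 1 and to compound 2 are both beyond the scatter, so compound 3 is the weakest inhibitor of the set.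

The next compound, compound 4, `COc1cc(C(=O)/C=C/c2c[nH]c3ccccc23)cc(SC)c1OC`, has not yet been measured. It differs from compound 3 in one place: methylsulfanyl in place of nitro on an aromatic carbon. Compound 4 thus carries the same methylsulfanyl group that compound 1 and compound 2 carry, and both of those give low numbers in this assay, while compound 3 with its nitro group is far weaker.

On this basis a sizeable step downward, beyond the scatter, is expected from compound 3 to compound 4, estimated as an 11-fold lower number from compound 3 to compound 4 (1.03 log units; beyond the scatter). Compound 4 is expected to give about 120 nM in this assay, with a likely range from 50 nM to 300 nM, because compound 1 gives 102 nM and compound 2 gives 101 nM.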

Compound 4, half-maximal inhibitory concentration: 186 nM
Estimate against measurement, compound 4: 1.6-fold (0.19 log units) below; measured number inside the range.
By their numbers in this assay, from the lowest: compounds 2, 1 and 4 (each within the scatter of the next); then compound 3.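

In this assay, methylsulfanyl in place of nitro on an aromatic carbon gives a 6.9-fold lower number from compound 3 to compound 4 (0.84 log units; beyond the scatter), so this one change, with the rest of the molecule held fixed, is enough to separate compound 3 from compound 4, something that compound 1 and compound 2 could not show because each differs from compound 3 in more than one place. The two neighbouring changes do not produce a comparable separation: hydrogen in place of methoxy on an aromatic carbon gives a 1.8-fold higher number from compound 2 to compound 4 (0.27 log units; within the scatter), and hydrogen in place of methyl on an aromatic nitrogen gives a 1.8-fold higher number from compound 1 to compound 4 (0.26 log units; within the scatter), both within the scatter, so neither step can be read as a real change in this assay. Nothing measured here explains why the swap from nitro to methylsulfanyl has this size.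

The compounds shown leave open how an amine, a chlorine atom or a longer chain such as ethylsulfanyl on this same aromatic carbon would compare with nitro and methylsulfanyl. They also leave open whether the sulfur atom matters, which a methoxy group at this carbon of the core of compound 4 would help to test.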